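Methoxy replacing hydrogen on the aryl of compound 2

The source may report more compounds than this note shows. Statements on the series, on what has been measured and on what is new or still open speak of the compounds shown alone.

Two numbers stand so far in an ADME assay on BHK-21 cells (Mesocricetus auratus) for cytotoxicity, read by MTT assay, with a stated time of 48 h; on this read-out higher numbers stand for lower toxicity in this test and lower numbers for higher toxicity in this test. Compound 2 `CC1(C)CC(=O)C2=C(C1)N(c1ccccc1)C(c1ccc(Br)cc1)N(c1ccc(Cl)cc1)C2` gives 12700 nM, the top of the pair. Among the compounds with values here, compound 1 `CC1(C)CC(=O)C2=C(C1)N(c1ccccc1)C(c1ccc(Br)cc1)N(c1ccc(F)cc1)C2` gives 10000 nM, and the only measured step, a 1.3-fold higher number from compound 1 to compound 2 (0.10 log units; within the scatter), stays within the scatter. Compound 3 `COc1ccc(N2C3=C(CN(c4ccc(Cl)cc4)C2c2ccc(Br)cc2)C(=O)CC(C)(C)C3)cc1` differs from compound 2 by methoxy in place of hydrogen on an aromatic carbon. Within the data shown here, no measured step touches this change; the one step on record, a halogen swap, moved nothing beyond the scatter. A step within the scatter, a 1.1-fold lower number from compound 2 to compound 3 (0.02 log units; within the scatter), is therefore expected. Compound 3 is estimated at 12000 nM, in the range 5500 nM to 26000 nM.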

Compound 3, half-maximal cytotoxic concentration: > 20000 nM
Compound 3: only a limit was reported (the forecaster's own chance of this, stated with the estimate: 20%); middle value at least 1.6-fold (0.22 log units) from the limit.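

In this assay, methoxy in place of hydrogen on this aromatic carbon, the phenyl to 4-methoxyphenyl change, gives an at least 1.5-fold higher number from compound 2 to compound 3 (0.19 log units; that floor lies within the scatter). The reading for compound 3 is a limit of the assay, not a number: the limit of > 20000 nM in this assay, at which 1 of the 3 values shown sits. Unlike the halogen swap, this change touches a different aryl, and it brings no lower number here, though the full size of the step cannot be read.

From the compounds shown here alone, whether the step truly lies beyond the scatter stays open. So does the outcome with an amine, a carboxylic acid or a longer chain at this position, and with methoxy on the fluoro partner, compound 1.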